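The source may hold more compounds than are shown below. What is called first, only, known or untested is meant among the compounds shown, and "the series" means these compounds.

Measured compounds:
- compound 1, `CC(=O)Nc1c(C(O)(C(F)(F)F)C(F)(F)F)ccc2ccccc12`: 18 nM
- compound 2, `CCCC(=O)Nc1c(C(O)(C(F)(F)F)C(F)(F)F)ccc2ccccc12`: 131 nM
- compound 3, `COc1cccc(C(=O)Nc2c(C(O)(C(F)(F)F)C(F)(F)F)ccc3ccccc23)c1`: 185 nM

In an assay on LtK cells with ATP-sensitive inward rectifier potassium channel 11 (Homo sapiens) as the target (a higher number here means that more compound is needed for the effect, a lower number that less compound is needed), compound 3 gives the highest of the three numbers; its step from compound 1 is a 10-fold higher number from compound 1 to compound 3 (1.01 log units; beyond the scatter), while compound 2 and compound 3 differ only by a 1.4-fold higher number from compound 2 to compound 3 (0.15 log units; within the scatter), which lies within the scatter. Compound 4, `O=C(Nc1c(C(O)(C(F)(F)F)C(F)(F)F)ccc2ccccc12)c1ccc(C(F)(F)F)cc1`, is not yet measured in this assay. It differs from compound 3 by 4-(trifluoromethyl)phenyl in place of 3-methoxyphenyl on a carbonyl carbon. Within the data shown here, two measured steps bear on an aryl group on the carbonyl carbon: a 10-fold higher number from compound 1 to compound 3 (1.01 log units; beyond the scatter) and a 1.4-fold higher number from compound 2 to compound 3 (0.15 log units; within the scatter). Both end at compound 3, and the second shows that a propyl and a 3-methoxyphenyl on the carbonyl carbon give numbers within the scatter of each other, so a second aryl group is not expected to move the number far. Among the measured compounds shown here, no measured pair separates a methoxy substituent from a trifluoromethyl one on the aryl group, so the direction is uncertain. Compound 4 is therefore expected to give about 200 nM in this assay, within 60 nM to 650 nM, a step of a 1.1-fold higher number from compound 3 to compound 4 (0.03 log units; within the scatter) that is estimated to stay within the scatter.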

Compound 4, half-maximal effective concentration: 160 nM
Compound 4: middle estimate off by 1.3-fold (0.10 log units), on the high side; low and high end bracket the measured number.
By their numbers in this assay, from the lowest: compound 1; then compounds 2, 4 and 3 (each within the scatter of the next).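

In this assay, among these compounds, the change from 3-methoxyphenyl to 4-(trifluoromethyl)phenyl on the carbonyl carbon gives a 1.2-fold lower number from compound 3 to compound 4 (0.06 log units; within the scatter) and so does not separate the two aryl groups, a comparison the earlier compounds could not offer. Against propyl, the new aryl group gives a 1.2-fold higher number from compound 2 to compound 4 (0.09 log units; within the scatter) and cannot be told apart from that chain either. Methyl alone stands apart at this position: with an 8.9-fold higher number from compound 1 to compound 4 (0.95 log units; beyond the scatter) as the new step, all three other groups on the carbonyl carbon now give numbers beyond the scatter of compound 1.

As far as these compounds go, whether an ethyl chain on the carbonyl carbon would give a number nearer compound 1 or compound 2 stays open, as does what an amine on the aryl group would do. Nothing available here explains why these three groups give such similar numbers.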